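Removing the 4-carboxybenzyl group from the sulfonamide nitrogen of compound 1

The source may report more compounds than this note shows. Statements on the series, on what has been measured and on what is new or still open speak of the compounds shown alone.

Compound 1 `O=C(O)c1ccc(CNS(=O)(=O)c2ccc3c(c2)cc(C(=O)O)n3Cc2ccc(C(=O)O)cc2)cc1` is the reference of this small series. Going by the values given here, in an assay on cells (Oocyte) for inhibition of pannexin-1 (Mus musculus), read by voltage clamp, tested at 50 uM, in the presence of a further agent that is not named here (on this read-out lower numbers stand for less inhibition and higher numbers for more inhibition at the one concentration tested (going by the name of the read-out)), compound 1 gives 100%, the highest of the three numbers known so far. Compound 3 `O=C(O)c1ccc(CN(Cc2ccc(C(=O)O)cc2)S(=O)(=O)c2ccc3c(c2)cc(C(=O)O)n3Cc2ccc(C(=O)O)cc2)cc1`, the nearest, gives 79%, and compound 2 `O=C(O)c1cn(Cc2ccccc2)c2ccc([N+](=O)[O-])cc12`, the furthest, gives 65%.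

Compound 4 `NS(=O)(=O)c1ccc2c(c1)cc(C(=O)O)n2Cc1ccc(C(=O)O)cc1` differs from compound 1 at one place: hydrogen in place of 4-carboxybenzyl on a sulfonamide nitrogen. Among the compounds with values here, the one measured step that bears on this position runs the other way: a number 21 percentage points lower from compound 1 to compound 3 (beyond the scatter). Taking that step in reverse would point upward, but compound 1 already sits at the top of the read-out, so there is no room in that direction. The nitro compound 2 shares neither the sulfonamide nor the same core and gives no guidance on this change.

The step from compound 1 to compound 4 is therefore expected to be small, a number 8 percentage points lower from compound 1 to compound 4 (within the scatter), and the number for compound 4 is estimated at 92%, within a range of 72% to 100%; any fall below the value of compound 1 would be read as ordinary scatter rather than a loss of inhibition.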

Compound 4, a percentage reported as inhibition, at one concentration (the size of the read-out at that concentration, not a potency): 61.7%
The estimate for compound 4 lay 30.3 percentage points above the measured number, and the stated range ends above it.
By their numbers in this assay, from the lowest: compounds 4 and 2 (each within the scatter of the next); then compound 3; then compound 1.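

In this assay, hydrogen in place of 4-carboxybenzyl on the sulfonamide nitrogen gives a number 38.3 percentage points lower from compound 1 to compound 4 (beyond the scatter), so the group of compound 1 cannot be removed without loss at the one concentration tested, although compound 4 still gives 61.7%. Read with the earlier step, a number 21 percentage points lower from compound 1 to compound 3 (beyond the scatter), which adds a second 4-carboxybenzyl on the same nitrogen, the result shows that change in either direction from compound 1 lowers the number, and that the single 4-carboxybenzyl gives the highest number of the three forms of this nitrogen shown. The data shown offer no measured basis for explaining this step.

The compounds shown leave open which part of the 4-carboxybenzyl group carries the step, the carboxylic acid or the aromatic ring, since they include no plain benzyl group on this nitrogen and no methyl group there. Also open, as far as these compounds go, is whether the distance matters, which a longer chain ending in a carboxylic acid would address, and a single-concentration read-out cannot say how any of these changes would affect potency.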